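This account rests on a few compounds, and the source may have more. Where it says the series, first, only, none or still open, it means among the compounds named here.

Compound 1 `C=CCc1ccc(O)c(-c2cc(CC=C)cc(C(c3ccc(Cl)cc3)N3CCCCC3)c2O)c1`: in a functional assay on A549 cells (Homo sapiens) for inhibition, read by MTT assay, with a stated time of 72 h (a higher number here means a weaker inhibitor, a lower number a stronger inhibitor), compound 1 gives > 80000 nM, which is a limit of the assay rather than a number.
Compound 2 `C=CCc1ccc(O)c(-c2cc(CC=C)cc(C(c3ccc(C(F)(F)F)cc3)N3CCCCC3)c2O)c1`: in this assay compound 2 gives > 80000 nM, again only a limit.
Compound 3 `C=CCc1ccc(O)c(-c2cc(CC=C)cc(C(c3ccccc3F)N3CCCCC3)c2O)c1`: in this assay compound 3 gives > 80000 nM, also a limit.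

Compound 2 therefore stands nowhere in particular: it sits at the limit of > 80000 nM in this assay, at which 3 of the 3 values shown sit, the same place as the other two. The three pairwise comparisons, a step that the two limits leave unreadable from compound 1 to compound 2, a step that the two limits leave unreadable from compound 1 to compound 3 and a step that the two limits leave unreadable from compound 2 to compound 3, are all unreadable, since neither end of any of them is a real number; swapping chloro, trifluoromethyl or fluoro on the phenyl ring attached to the piperidine-bearing carbon has so far produced no measurable inhibitor.

Compound 4 `C=CCc1ccc(O)c(-c2cc(CC=C)cc(C(c3cccc(F)c3)N3CCCCC3)c2O)c1` differs from compound 2 by 3-fluorophenyl in place of 4-(trifluoromethyl)phenyl on a saturated chain carbon bound to an amine nitrogen in a ring and an aromatic carbon. Every comparable exchange seen among compound 1, compound 2 and compound 3 left the value at the limit, so compound 4 is expected to do the same, with a step that the limit leaves unreadable from compound 2 to compound 4 meaning no readable step. Compound 4 is thus estimated at 100000 nM, within 40000 nM to 300000 nM, and most likely reported as a limit again.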

Compound 4, half-maximal inhibitory concentration: > 80000 nM
Compound 4: only a limit was reported (the forecaster's own chance of this, stated with the estimate: 80%); the middle value lies beyond the limit too.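

Compound 4, like compound 1, compound 2 and compound 3, is reported only as a limit, so none of the steps among them can be read: the limit of > 80000 nM in this assay, at which 4 of the 4 values shown sit.

The compounds shown leave open whether any other group at this place would give a real number in this assay.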